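This account rests on a few compounds, and the source may have more. Where it says the series, first, only, none or still open, it means among the compounds named here.

In an ADME assay on HCT-116 cells (Homo sapiens) for cytotoxicity, read by CellTiter-Glo, with a stated time of 72 h (a lower number here means a stronger inhibitor, a higher number a weaker inhibitor), compound 1 `CC1CCN(C2CCN(S(=O)(=O)c3cccnc3)CC2)CC1` gives > 10000 nM, a value that is a limit of the assay rather than a number. Compound 2 `CC1CCN(C2CCN(S(=O)(=O)c3ccccc3-c3ccccc3)CC2)CC1` also reaches only a limit in this assay, giving > 5000 nM. Compound 3 `CC1CCN(C2CCN(S(=O)(=O)c3ccc(Cl)cc3Cl)CC2)CC1` differs from compound 1 by 2,4-dichlorophenyl in place of pyridin-3-yl on a sulfonyl sulfur. Going by the values given here, no step between measured compounds has been recorded, so nothing here points to a shift of any size; the expected step is a step that the limit leaves unreadable from compound 1 to compound 3, no change beyond the usual scatter. Compound 3 is expected to sit at 15000 nM, with a likely range from 5000 nM to 50000 nM.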

Compound 3, half-maximal inhibitory concentration: > 5000 nM
Compound 3 was reported as a limit; the forecaster's own chance of this, stated with the estimate: 75%; the middle value lies beyond the limit too.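

Going by these compounds alone, compound 1 and compound 3 each reach only a limit in this assay, and no step between them can be read. The compounds shown leave open whether 2,4-dichlorophenyl in place of pyridin-3-yl changes this cytotoxicity at all.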